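Caco-2 permeability after removing the dimethylpyrazole

The source may report more compounds than this note shows. Statements on the series, on what has been measured and on what is new or still open speak of the compounds shown alone.

Compound 1 `CC(C)Oc1cc(-c2cncc(-c3cnn(C4COC4)c3)c2)ccc1C(N)=O` gives 10 10^-6 cm/s in an ADME assay on Caco-2 cells (Homo sapiens) for permeability; a higher number here means that the compound crosses the layer faster, a lower number that the compound crosses the layer more slowly
Compound 2 `Cc1c(-c2cncc(-c3ccc(C(N)=O)c(OC(C)C)c3)c2)cnn1C` gives 27 10^-6 cm/s in this assay

Of the two measured compounds, compound 2 stands higher, with 27 10^-6 cm/s as its value. Compound 3 `CC(C)Oc1cc(-c2cccnc2)ccc1C(N)=O` differs from it by one change hydrogen in place of 1,5-dimethyl-1H-pyrazol-4-yl on an aromatic carbon in which hydrogen comes in place of 1,5-dimethyl-1H-pyrazol-4-yl on an aromatic carbon. Among the measured compounds shown here, only one measured step bears on this: a 2.7-fold higher number from compound 1 to compound 2 (0.43 log units; beyond the scatter) which is modest and swaps one group for another. For the measured compounds named here, no measured compound lacks the group altogether, so the data give only weak guidance on its removal. In this assay a small rise that stays within the scatter is expected, with a wide margin on both sides. The expected step is a 1.4-fold higher number from compound 2 to compound 3 (0.15 log units; within the scatter) as a cautious guess. The estimated value for compound 3 is 38 10^-6 cm/s (15 10^-6 cm/s to 80 10^-6 cm/s).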

Compound 3, apparent permeability: 32 10^-6 cm/s
Compound 3: the middle estimate sits 1.2-fold (0.07 log units) above what was measured; the measured number falls inside the stated range.
By their numbers in this assay, from the lowest: compound 1; then compounds 2 and 3 (each within the scatter of the next).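

Putting hydrogen in place of the 1,5-dimethyl-1H-pyrazol-4-yl on this aromatic carbon gives a 1.2-fold higher number from compound 2 to compound 3 (0.07 log units; within the scatter) in this assay, so the number stays within the scatter even with that whole five-membered aromatic ring gone. Putting hydrogen in place of the 1-(oxetan-3-yl)-1H-pyrazol-4-yl gives a 3.2-fold higher number from compound 1 to compound 3 (0.51 log units; beyond the scatter), which sets compound 1 apart from both of the other compounds, while compound 2 and compound 3 cannot be told apart in this read-out. No measurement shown here explains why these numbers fall as they do.

Going by these compounds, it remains open whether the lower number of compound 1 goes with the oxetane ring itself or with the pyrazole that carries it. On these data alone, how a small group such as an amine or a carboxylic acid would read on this same aromatic carbon also remains open.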